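The source may hold more compounds than are shown below. What is called first, only, known or untested is meant among the compounds shown, and "the series" means these compounds.

Measured compounds:
Compound 1 `Cn1cc(SCc2nnc(SCc3ccccc3C#N)n2-c2c(Cl)cccc2Cl)c2ccccc21`: in a toxicity assay on HEK-293T cells (Homo sapiens) for cytotoxicity, read by CCK-8 assay, with a stated time of 48 h (on this read-out lower numbers stand for higher toxicity in this test and higher numbers for lower toxicity in this test), compound 1 gives 78600 nM.
Compound 2 `Cn1cc(SCc2nnc(SCc3ccccc3OC(F)(F)F)n2-c2c(Cl)cccc2Cl)c2ccccc21`: in this assay compound 2 reaches only the assay limit, > 100000 nM.
Compound 3 `Cn1cc(SCc2nnc(SCc3cc(C(F)(F)F)ccc3Cl)n2-c2c(Cl)cccc2Cl)c2ccccc21`: in this assay compound 3 gives 53800 nM.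

Compound 3 carries the lower of the two plain numbers; its nearest neighbour is compound 1, and that gap, a 1.5-fold lower number from compound 1 to compound 3 (0.16 log units; within the scatter), stays within the scatter. The remaining value is a limit (the limit of > 100000 nM in this assay, at which 1 of the 3 values shown sits).

Compound 4 `Cn1cc(SCc2nnc(SCc3cccc(Cl)c3Cl)n2-c2c(Cl)cccc2Cl)c2ccccc21` differs from compound 3 by 2,3-dichlorophenyl in place of 2-chloro-5-(trifluoromethyl)phenyl on a saturated chain carbon bound to a sulfur. The exchanges already measured at this position, a 1.5-fold lower number from compound 1 to compound 3 (0.16 log units; within the scatter) and an at least 1.8-fold lower number from compound 2 to compound 3 (0.26 log units; that floor lies within the scatter), both sit within the scatter, as does an at least 1.2-fold higher number from compound 1 to compound 2 (0.10 log units; that floor lies within the scatter). No step beyond the scatter is therefore expected in this assay.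

Compound 4 is estimated at 60000 nM, between 30000 nM and 120000 nM, the expected step being a 1.1-fold higher number from compound 3 to compound 4 (0.05 log units; within the scatter).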

Compound 4, half-maximal cytotoxic concentration: > 100000 nM
Compound 4: no number, only a limit (the forecaster's own chance of this, stated with the estimate: 25%); middle value at least 1.6-fold (0.22 log units) from the limit.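

In this assay compound 4 stops at a limit, not a number (> 100000 nM). The steps of an at least 1.8-fold higher number from compound 3 to compound 4 (0.26 log units; that floor lies within the scatter) and an at least 1.2-fold higher number from compound 1 to compound 4 (0.10 log units; that floor lies within the scatter) are only floors, so no change beyond the scatter can be claimed at this saturated chain carbon bound to a sulfur. The step between compound 2 and compound 4 cannot be read, and a second aryl group now ends at the limit: the limit of > 100000 nM in this assay, at which 2 of the 4 values shown sit.

Open, from the compounds shown here alone, is whether an amine or a carboxylic acid on the phenyl group would give a step beyond the scatter. Going by these compounds, a longer chain in place of the benzyl carbon is equally open.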